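A few compounds are considered here, and "the series" means these few. Any claim that something is new, unique, unknown or untested is made for them only; others in the source may bear on it.

Compound 1, `N#Cc1cc(=O)[nH]c(=O)n1[C@@H]1O[C@H](CO)[C@@H](O)[C@H]1O`, in a functional assay on COLO 205 cells (Homo sapiens) for antiproliferative activity, read by WST assay, with a stated time of 3 days (on this read-out higher numbers stand for weaker inhibition and lower numbers for stronger inhibition), gives > 50000 nM, a limit of the assay.
Compound 2, `[N-]=[N+]=Nc1cc(=O)[nH]c(=O)n1[C@@H]1O[C@H](CO)[C@@H](O)[C@H]1O`, in this assay gives > 50000 nM, again a limit.
Compound 3, `COC(=O)c1cc(=O)[nH]c(=O)n1[C@@H]1O[C@H](CO)[C@@H](O)[C@H]1O`, in this assay gives > 50000 nM, also a limit.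

Compound 2 therefore stands at the upper limit of this assay, and so do both of its neighbours; all three values sit at the limit of > 50000 nM in this assay, at which 3 of the 3 values shown sit. The step that the two limits leave unreadable from compound 1 to compound 2 cannot be sized, nor can a step that the two limits leave unreadable from compound 1 to compound 3 or a step that the two limits leave unreadable from compound 2 to compound 3, since each pair is bounded by two limits and no number. Within this set, exchanging one small substituent on the aromatic carbon of the shared core for another has not brought any compound into the measurable range.

Compound 4, `CN(C)c1cc(=O)[nH]c(=O)n1[C@@H]1O[C@H](CO)[C@@H](O)[C@H]1O`, differs from compound 2 in one place: dimethylamino in place of azido on an aromatic carbon. The measured steps that bear on this change are those between compounds 1, 2 and 3, and none of them is readable. With every comparison blocked by the limit, there is no ground for expecting compound 4 to move beyond the scatter in either direction. The step that the limit leaves unreadable from compound 2 to compound 4 is therefore expected to be flat. Compound 4 is estimated at 60000 nM in this assay, with a range from 20000 nM to 200000 nM, and most likely a further limit rather than a number.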

Compound 4, half-maximal inhibitory concentration: > 50000 nM
Compound 4: no number, only a limit; the forecaster's own chance of this, stated with the estimate: 85%; the middle value lies beyond the limit too.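

In this assay compound 4 gives > 50000 nM, again a limit and not a number. No step to compound 4 from compound 1, compound 2 or compound 3 can therefore be read: the limit of > 50000 nM in this assay, at which 4 of the 4 values shown sit.

The compounds shown leave open how these four compare with one another, and whether any substituent on this aromatic carbon of the shared core gives a measurable value.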